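From hydroxy to 2-methoxyethoxy on compound 3

This account rests on a few compounds, and the source may have more. Where it says the series, first, only, none or still open, it means among the compounds named here.

In a physicochemical assay for lipophilicity, read by HPLC, in phosphate buffer, measured as octanol-water partition, at pH 7.4, tested at 100 uM (on this read-out higher numbers stand for higher lipophilicity and lower numbers for lower lipophilicity), compound 3 `Cc1cc(O)ccc1-c1cccc(CNc2ccc(OCC(=O)O)c(F)c2)c1` gives 1.85, the lowest of three numbers, against compound 1 `Cc1ccccc1-c1cccc(CNc2ccc(OCC(=O)O)c(F)c2)c1` at 2.41 and compound 2 `CCOc1ccc(-c2cccc(CNc3ccc(OCC(=O)O)c(F)c3)c2)c(C)c1` at 2.83. Compound 4 `COCCOc1ccc(-c2cccc(CNc3ccc(OCC(=O)O)c(F)c3)c2)c(C)c1` carries 2-methoxyethyl in place of hydrogen on an oxygen on an aromatic ring.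

For the measured compounds named here, three measured steps bear on this change. The closest is a number 0.98 log units lower from compound 2 to compound 3 (beyond the scatter), with hydrogen in place of ethyl on an oxygen on an aromatic ring, and read in reverse it points upward. The other two frame it: a number 0.56 log units lower from compound 1 to compound 3 (beyond the scatter) for hydroxy and a number 0.42 log units higher from compound 1 to compound 2 (beyond the scatter) for ethoxy. Going by the values given here, no measured compound shows how 2-methoxyethyl compares with ethyl, so compound 4 is expected near compound 2, perhaps slightly under it. A modest rise is expected, and the estimated step is a number 0.75 log units higher from compound 3 to compound 4 (beyond the scatter). For compound 4 the estimated value is 2.6, with an expected range from 2.3 to 2.95.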

Compound 4, distribution coefficient: 2.23
For compound 4 the middle estimate is 0.37 log units above the measured one; the whole stated range lies above it.
By their numbers in this assay, from the lowest: compound 3; then compounds 4 and 1 (each within the scatter of the next); then compound 2.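

In this assay, putting 2-methoxyethyl on the oxygen gives a rise of its own, a number 0.38 log units higher from compound 3 to compound 4 (beyond the scatter), smaller in size than the gap that ethyl opens on the same oxygen, a number 0.98 log units lower from compound 2 to compound 3 (beyond the scatter) when read backwards. For the compounds shown here, what the earlier compounds did not show is that this position also responds further out on the chain: methoxy in place of hydrogen on a saturated chain carbon gives a number 0.60 log units lower from compound 2 to compound 4 (beyond the scatter), while the whole 2-methoxyethoxy group, set against hydrogen on the aromatic carbon, gives a number 0.18 log units lower from compound 1 to compound 4 (within the scatter), so those two compounds cannot be told apart here. The data at hand offer no explanation for these differences.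

Only ethyl and 2-methoxyethyl show how this oxygen behaves when capped. From the compounds shown here alone, how a longer chain, such as 3-methoxypropyl, or a chain ending in an amine or a carboxylic acid would read remains open.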